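A Longer, Straight Hydroxyalkyl Chain on the Amide Nitrogen

A few compounds are considered here, and "the series" means these few. Any claim that something is new, unique, unknown or untested is made for them only; others in the source may bear on it.

Compound 2 `CCC(CO)NC(=O)c1cc2cccc(OC)c2oc1=N`, compound 1 `COCCNC(=O)c1cc2cccc(OC)c2oc1=N` and compound 3 `N=c1oc2ccc(Br)cc2cc1C(=O)NC1CCCC1` share one core and carry different groups on the amide nitrogen. In an assay on CHO cells for displacement of a labelled ligand from adenosine receptor A1 (Homo sapiens), read by scintillation counting, with a stated time of 60 min, tested at 10 uM (on this read-out higher numbers stand for more inhibition at the one concentration tested (going by the name of the read-out) and lower numbers for less inhibition), compound 2 gives 24%. Compound 3 gives 17%, a difference from compound 2 that lies within the usual scatter. Compound 1 gives > 70%, which is a limit of the assay (the limit of > 70% in this assay, at which 1 of the 3 values shown sits). For the measured compounds named here, the only measured step that touches the amide substituent is a number at least 46 percentage points lower from compound 1 to compound 2 (beyond the scatter), showing that this position can move the read-out strongly. Compound 4 `COc1cccc2cc(C(=O)NCCCCCO)c(=N)oc12` carries 5-hydroxypentyl in place of 1-(hydroxymethyl)propyl on an amide-type nitrogen. Guided by that single large step, a moderate rise is expected, a number 16 percentage points higher from compound 2 to compound 4 (beyond the scatter). Compound 4 is therefore estimated at 40%, ranging from 15% to 70%.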

Compound 4, a percentage reported as inhibition, at one concentration (the size of the read-out at that concentration, not a potency): 44%
Estimate against measurement, compound 4: 4 percentage points below; low and high end bracket the measured number.
By their numbers in this assay, from the lowest: compounds 3 and 2 (each within the scatter of the next); then compound 4. At a limit, above all of these: compound 1.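

With 5-hydroxypentyl in place of 1-(hydroxymethyl)propyl, this assay gives a number 20 percentage points higher from compound 2 to compound 4 (beyond the scatter) even though both groups have one hydrogen-bond donor and one acceptor, so these counts alone do not set the read-out at this position. The step of a number at least 26 percentage points lower from compound 1 to compound 4 (beyond the scatter) still separates 5-hydroxypentyl from 2-methoxyethyl. The value of compound 1 is a limit: the limit of > 70% in this assay, at which 1 of the 4 values shown sits.

On these data alone, whether a longer chain would raise the number further remains open. So does the effect of an amine or a carboxylic acid in place of the hydroxyl at the chain end.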